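Swapping a Tert-Butyl for a Sulfonamide on the Triazole

The source may hold more compounds than are shown below. What is called first, only, known or untested is meant among the compounds shown, and "the series" means these compounds.

Of the compounds shown here, three sharing one lactone core have been tested in a functional assay on HepG2 cells (Homo sapiens) for antiproliferative activity, read by MTT assay, with a stated time of 72 h; on this read-out lower numbers stand for stronger inhibition and higher numbers for weaker inhibition. Compound 1 `Cc1ccc(-c2cn(C/C=C3\OC(=O)C(OCc4ccccc4)=C3OCc3ccccc3)nn2)cc1` reaches only the limit > 100000 nM, which is a boundary of the assay and not a number. Compound 2 `CCCCCCCCCCc1cn(C[C@H](O)[C@H]2OC(=O)C(OCc3ccccc3)=C2OCc2ccccc2)nn1` gives 12200 nM. Compound 3 `CC(C)(C)c1cn(C[C@H](O)[C@H]2OC(=O)C(OCc3ccccc3)=C2OCc2ccccc2)nn1`, differing from it by a tert-butyl in place of decyl on an aromatic carbon, gives 29200 nM and so stands highest of the two measured numbers; the step of a 2.4-fold higher number from compound 2 to compound 3 (0.38 log units; beyond the scatter) is modest but beyond the scatter.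

Compound 4 `Cc1ccc(S(=O)(=O)NCc2cn(C[C@H](O)[C@H]3OC(=O)C(OCc4ccccc4)=C3OCc3ccccc3)nn2)cc1` carries (((4-methylphenyl)sulfonyl)amino)methyl in place of tert-butyl on an aromatic carbon. For the measured compounds named here, the only measured step at this position, from decyl to tert-butyl, moved the number modestly; compound 1, which bears an aromatic group on the same ring but also a different linker, reached only a limit. The new group is far larger and more polar than anything tried at this spot, so the direction is uncertain. The step of a 1.2-fold lower number from compound 3 to compound 4 (0.07 log units; within the scatter) is expected to stay small. Compound 4 is therefore estimated at 25000 nM, with a range from 8000 nM to 100000 nM.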

Compound 4, half-maximal inhibitory concentration: 24900 nM
Beside the measured number, compound 4's estimate is 1.0-fold (0.00 log units) above it; low and high end bracket the measured number.
By their numbers in this assay, from the lowest: compound 2; then compounds 4 and 3 (each within the scatter of the next). At a limit, above all of these: compound 1.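

In this assay, replacing tert-butyl with (((4-methylphenyl)sulfonyl)amino)methyl gives a 1.2-fold lower number from compound 3 to compound 4 (0.07 log units; within the scatter). This position on the triazole therefore accepts a group with many more heavy atoms, a six-membered aromatic ring and a hydrogen-bond donor, with no change in the number that can be told from scatter. The decyl group of compound 2 still stands apart, with a 2.0-fold higher number from compound 2 to compound 4 (0.31 log units; beyond the scatter), so among these three compounds the substituent can shift the number, but only modestly.

Nothing shown here explains why such different groups give such close numbers. Also open, from the compounds shown here alone, is what a primary amine, a carboxylic acid or a chain longer than decyl would do at this position, and whether any group there could bring the number far below that of compound 2.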